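The source may report more compounds than this note shows. Statements on the series, on what has been measured and on what is new or still open speak of the compounds shown alone.

Of the compounds shown here, three of this set have been read in an ADME assay on HEK293 cells (Homo sapiens) for cytotoxicity, read by resazurin assay, with a stated time of 24 h; a lower number here means that less compound is tolerated, a higher number that more compound is tolerated. Compound 1 `O=C(O)c1c(O)cc(Cl)cc1C=Cc1ccc2ccccc2c1` gives 38000 nM in this assay. Compound 2 `COc1cc(Cl)cc(C=Cc2ccc3ccccc3c2)c1C(=O)O` differs from compound 1 by methyl in place of hydrogen on an oxygen on an aromatic ring; in this assay compound 2 gives 93000 nM, so that a 2.4-fold higher number from compound 1 to compound 2 (0.39 log units; beyond the scatter). Compound 3 `CCN(CC)C(=O)c1c(O)cccc1CCc1ccc2ccccc2c1` rests on another core, and the difference between its core and the core of compound 1 is not broken down here. In this assay compound 3 reaches only a limit of the assay and not a number, namely > 100000 nM. That reading sits at the limit of > 100000 nM in this assay, at which 1 of the 3 values shown sits.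

Compound 4 `CCN(CC)C(=O)c1c(CCc2ccc3ccccc3c2)cccc1OC` has not yet been measured in this assay. It differs from compound 3 by methyl in place of hydrogen on an oxygen on an aromatic ring, and this is the same change that was made from compound 1 to compound 2, at the same kind of place on each core. On the strength of that earlier step, in which compound 2 came out tolerated to a higher number than compound 1 after the same methylation, the expected step from compound 3 to compound 4 is a step that the limit leaves unreadable from compound 3 to compound 4, in the same direction as before. Since compound 3 already sits at the upper limit of the assay, compound 4 is expected to come out again as a limit rather than as a number in most repeats. The estimate for compound 4 in this assay is 180000 nM. The expected range for compound 4 runs from 70000 nM to 500000 nM.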

Compound 4, half-maximal cytotoxic concentration: 85700 nM
Beside the measured number, compound 4's estimate is 2.1-fold (0.32 log units) above it; low and high end bracket the measured number.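

In this assay, the change from hydroxy to methoxy gives an at least 1.1-fold lower number from compound 3 to compound 4 (0.06 log units; that floor lies within the scatter), which does not repeat the rise seen on the core of compound 1, and the two steps differ by more than the scatter: the same change on two cores in this assay, a 2.4-fold higher number (0.39 log units; beyond the scatter) from compound 1 to compound 2 and an at least 1.1-fold lower number (0.06 log units; that floor lies within the scatter) from compound 3 to compound 4, at least 2.8-fold (0.45 log units) apart, beyond the scatter of two such steps

The change therefore does not carry from one core to the other as a fixed step, although one pair on each core shows only that the two outcomes differ and not why they do. Going by these compounds, compound 3 carries a limit of the assay and not a number, > 100000 nM, so the step has only a floor, which itself lies within the scatter, and its real size remains unknown.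

On these data alone, the two cores differ in more than one place, so it stays open which difference separates the two steps: the carboxylic acid against the diethyl amide, the chlorine, or the link between the ring systems. Also open, as far as these compounds go, is how a longer chain on that oxygen, or an amine elsewhere on either core, would read in this assay.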